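Dropping the carboxymethyl arm: what compound 3 might show

The source may hold more compounds than are shown below. What is called first, only, known or untested is meant among the compounds shown, and "the series" means these compounds.

compound 1 `COC(=O)CC1(C(=O)Nc2cccc(C(=N)N)c2)CC(c2cccc(C(=N)N)c2)=NO1`: 230 nM
compound 2 `N=C(N)c1ccc(NC(=O)C2(CC(=O)O)CC(c3cccc(C(=N)N)c3)=NO2)cc1`: > 1200 nM

In an assay on isolated protein for inhibition of serine protease 1 (Homo sapiens) (on this read-out higher numbers stand for weaker inhibition and lower numbers for stronger inhibition), compound 1 gives 230 nM. For compound 2 the reading of > 1200 nM is only a limit of this assay, not a number, namely (the limit of > 1200 nM in this assay, at which 1 of the 2 values shown sits). Compound 3 `N=C(N)c1ccc(NC(=O)C2CC(c3cccc(C(=N)N)c3)=NO2)cc1` differs from compound 2 by hydrogen in place of carboxymethyl on a saturated ring carbon. Among the compounds with values here, no measured pair shows this change, so the size of the step in this assay is open; a gain beyond the scatter is expected, though a loss cannot be ruled out. Compound 3 is estimated at 800 nM, between 150 nM and 4000 nM. For compound 3 this estimate means an expected step of an at least 1.5-fold lower number from compound 2 to compound 3 (0.17 log units; that floor lies within the scatter).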

Compound 3, inhibition constant: 700 nM
The estimate for compound 3 lay 1.1-fold (0.06 log units) above the measured number; measured number inside the range.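

In this assay, hydrogen in place of carboxymethyl on this saturated ring carbon gives an at least 1.7-fold lower number from compound 2 to compound 3 (0.23 log units; that floor lies within the scatter). Compound 3 thus gives a measured number with no carboxymethyl arm at this position. The reading for compound 2 is only a limit, so the full size of the step stays unknown: the limit of > 1200 nM in this assay, at which 1 of the 3 values shown sits.

Going by these compounds, whether the step goes beyond the scatter remains open. Also open, on these data alone, is what an amine or a single methyl group on this ring carbon would give compared with hydrogen.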